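Methoxy in Place of Fluoro: an Expectation for Compound 4

A few compounds are considered here, and "the series" means these few. Any claim that something is new, unique, unknown or untested is made for them only; others in the source may bear on it.

Four compounds share a core and differ in how a six-membered aromatic ring is attached and substituted. Compound 1 `Fc1cccc(Cc2nnc(Cn3nnc4ccccc43)o2)c1` and compound 2 `COc1cccc(Cc2nnc(Cn3nnc4ccccc43)o2)c1` differ by one change, (methoxy in place of fluoro on an aromatic carbon), and the result in a functional assay on MCF7 cells (Homo sapiens) for antiproliferative activity, read by MTT assay, with a stated time of 24 h (a lower number here means a stronger inhibitor, a higher number a weaker inhibitor), is a 1.5-fold lower number from compound 1 to compound 2 (0.17 log units; within the scatter). In this assay compound 1 gives 357000 nM and compound 2 gives 241000 nM. Compound 3 `Fc1cccc(-c2nnc(Cn3nnc4ccccc43)o2)c1` carries a different core; the difference between the two cores is not broken down here. In this assay compound 3 gives 398000 nM. Compound 4 `COc1cccc(-c2nnc(Cn3nnc4ccccc43)o2)c1` differs from compound 3 by methoxy in place of fluoro on an aromatic carbon, the same change as between compound 1 and compound 2, at the same place. For compound 4 the expected step is a 1.5-fold lower number from compound 3 to compound 4 (0.17 log units; within the scatter), which rests on the earlier result a 1.5-fold lower number from compound 1 to compound 2 (0.17 log units; within the scatter). Compound 4 is thus estimated at 270000 nM, expected between 150000 nM and 480000 nM.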

Compound 4, half-maximal inhibitory concentration: 370000 nM
Compound 4: the middle estimate sits 1.4-fold (0.14 log units) below what was measured; the measured number falls inside the stated range.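

In this assay, methoxy in place of fluoro gives a 1.1-fold lower number from compound 3 to compound 4 (0.03 log units; within the scatter), and this step can be set beside the one seen on the other core. The two steps agree, so on these two cores the change carries over without a detectable difference: the same change on two cores in this assay, a 1.5-fold lower number (0.17 log units; within the scatter) from compound 1 to compound 2 and a 1.1-fold lower number (0.03 log units; within the scatter) from compound 3 to compound 4, 1.4-fold (0.14 log units) apart, within the scatter of two such steps. Both steps lie within the scatter, however, so neither shows that the change itself moves the number, and two pairs say nothing about how it would behave on other cores.

Still open, on these data alone, is whether a different group in the same place, such as an amine, a carboxylic acid or a longer chain, would give a step beyond the scatter. Also open, as far as these compounds go, is whether methoxy in place of fluoro would give the same result elsewhere on the ring.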